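Working notes: the step from compound 2 to compound 3

This account rests on a few compounds, and the source may have more. Where it says the series, first, only, none or still open, it means among the compounds named here.

Measured in a functional assay on MCF7 cells (Homo sapiens) for antiproliferative activity, read by sulforhodamine B assay, with a stated time of 48 h; on this read-out higher numbers stand for weaker inhibition and lower numbers for stronger inhibition:
- compound 1 `Cc1cccc(OS(=O)(=O)c2ccc(N3CCN(C)C3=O)cc2)c1`: 5100 nM
- compound 2 `CN1CCN(c2ccc(S(=O)(=O)Oc3cccc(Cl)c3)cc2)C1=O`: 2200 nM

Compound 2 gives the lower of the two numbers, at 2200 nM. Compound 3 `Cc1ccc(OS(=O)(=O)c2ccc(N3CCN(C)C3=O)cc2)cc1`, not yet measured, differs from it by 4-methylphenyl in place of 3-chlorophenyl on an oxygen. For the measured compounds named here, the one measured step that bears on this is a 2.3-fold lower number from compound 1 to compound 2 (0.37 log units; beyond the scatter), modest and beyond the scatter, with chloro in place of methyl on an aromatic carbon. Going by the values given here, compound 3 also carries methyl, so that step read in reverse points to a higher number, though no measured step covers the change to 4-methylphenyl itself. The expected step, of similar size, is a 2.3-fold higher number from compound 2 to compound 3 (0.36 log units; beyond the scatter). For compound 3 the estimate is 5000 nM, with an expected range of 2000 nM to 12000 nM.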

Compound 3, half-maximal inhibitory concentration: > 100000 nM
Compound 3 was reported as a limit; the forecaster's own chance of this, stated with the estimate: 5%; at least 20-fold (1.30 log units) between middle value and limit.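

Compound 3 is reported in this assay only as a limit, not as a number: the limit of > 100000 nM in this assay, at which 1 of the 3 values shown sits.

Both new steps are large, an at least 45-fold higher number from compound 2 to compound 3 (1.65 log units; beyond the scatter) and an at least 19-fold higher number from compound 1 to compound 3 (1.29 log units; beyond the scatter). The second keeps methyl and changes only 3-methylphenyl to 4-methylphenyl on the oxygen, so the change of group alone outweighs a 2.3-fold lower number from compound 1 to compound 2 (0.37 log units; beyond the scatter).

Going by these compounds, the true size of both new steps remains open, given that limit. Also open, on these data alone, is whether 4-chlorophenyl, or a phenyl carrying an amine or a carboxylic acid, would follow 4-methylphenyl or the 3-substituted groups.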